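The source may report more compounds than this note shows. Statements on the series, on what has been measured and on what is new or still open speak of the compounds shown alone.

In an ADME assay on L02 cells (Homo sapiens) for cytotoxicity, read by MTT assay, with a stated time of 24 h (on this read-out lower numbers stand for stronger inhibition and higher numbers for weaker inhibition), compound 1 (`COc1cc(/C=C2\CN(C)C/C(=C\c3ccccc3F)C2=O)cc(OC)c1`) gives 11900 nM and compound 2 (`COc1cc(/C=C2\CN(C)C/C(=C\c3ccc(Cl)c(Cl)c3)C2=O)cc(OC)c1`) gives 10600 nM and these two values lie within the scatter of each other. Compound 3 (`COc1cc(/C=C2\CN(C)C/C(=C\c3ccc(Cl)c(Cl)c3)C2=O)cc(OC)c1OC`) carries one change from compound 2 (methoxy in place of hydrogen on an aromatic carbon), namely methoxy in place of hydrogen on an aromatic carbon, ortho to two methoxy groups and para to a large group. Within the data shown here, no measured step covers that place. Among the measured compounds shown here, the only step available (a 1.1-fold lower number from compound 1 to compound 2 (0.05 log units; within the scatter)) puts 3,4-dichlorophenyl in place of 2-fluorophenyl at a different place and stays within the scatter. With only this to go on, no step beyond the scatter is expected in this assay for the new methoxy. The estimated step (a 1.1-fold lower number from compound 2 to compound 3 (0.05 log units; within the scatter)) is accordingly small. Compound 3 is expected at an estimated 9500 nM with a range from 4500 nM to 20000 nM as the working figure.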

Compound 3, half-maximal inhibitory concentration: 18400 nM
Compound 3: the middle estimate sits 1.9-fold (0.29 log units) below what was measured, and the stated range covers the measured number.
By their numbers in this assay, from the lowest: compounds 2, 1 and 3 (each within the scatter of the next).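

In this assay, among these compounds, the first reading at this position is a 1.7-fold higher number from compound 2 to compound 3 (0.24 log units; within the scatter) for methoxy in place of hydrogen on an aromatic carbon, ortho to two methoxy groups and para to a large group. The earlier pair spoke only to the aryl group on the other side of the shared core, whereas this step shows that adding a third methoxy to the dimethoxy-substituted ring, with the 3,4-dichlorophenyl group in place, gives no change beyond the scatter on this cytotoxicity read-out. Nothing available bears on the reason for this result.

Still open, as far as these compounds go, is whether an amine, a carboxylic acid or a longer chain such as butoxy at this same position would give a step beyond the scatter. Also open, from the compounds shown here alone, is whether the methoxy step would stay this small with 2-fluorophenyl on the other side.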